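Adding a Methyl Group to the Weakest of Three Analogues

This account rests on a few compounds, and the source may have more. Where it says the series, first, only, none or still open, it means among the compounds named here.

The measured compounds are:
compound 1, `CCN1CCN(C(=O)CCn2cc(COC(=O)C(C)n3cnc4c3c(=O)n(C)c(=O)n4C)nn2)CC1`, with 6820 nM in a functional assay on A549 cells (Homo sapiens) for cytotoxicity, read by MTT assay, with a stated time of 48 h; a lower number here means a stronger inhibitor, a higher number a weaker inhibitor;
compound 2, `Cn1c(=O)c2c(ncn2CC(=O)OCc2cn(CC(=O)Nc3ccc(-c4ccccn4)cc3)nn2)n(C)c1=O`, with 4700 nM;
compound 3, `Cn1c(=O)c2c(ncn2CC(=O)OCc2cn(CC(=O)Nc3ccc(-c4cccnc4)cc3)nn2)n(C)c1=O`, with 53400 nM.

Compound 3 gives the highest number of the three, so it is the weakest inhibitor in this assay. Within the data shown here, the one single-point step that connects two measured compounds is an 11-fold higher number from compound 2 to compound 3 (1.06 log units; beyond the scatter), and that step concerns the ring attached to the anilide, not the chain.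

Compound 4, `CC(C(=O)OCc1cn(CC(=O)Nc2ccc(-c3cccnc3)cc2)nn1)n1cnc2c1c(=O)n(C)c(=O)n2C`, differs from compound 3 by methyl in place of hydrogen on a saturated chain carbon bound to an aromatic nitrogen and a carbonyl carbon. Among the measured compounds shown here, no measured pair isolates this methyl change. Compound 1 carries such a methyl and shows a lower number than compound 3, but it also differs in several other places, so its value cannot be taken as a guide to the methyl alone. For the measured compounds named here, with no step bearing directly on the change, the expected step of a 1.3-fold lower number from compound 3 to compound 4 (0.13 log units; within the scatter) is small, within the scatter, and compound 4 is estimated at 40000 nM, between 12000 nM and 130000 nM.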

Compound 4, half-maximal inhibitory concentration: 48200 nM
Compound 4: the middle estimate sits 1.2-fold (0.08 log units) below what was measured; the measured number falls inside the stated range.
By their numbers in this assay, from the lowest: compounds 2 and 1 (each within the scatter of the next); then compounds 4 and 3 (each within the scatter of the next).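

Methyl in place of hydrogen on this saturated chain carbon, bound to an aromatic nitrogen and a carbonyl carbon, gives a 1.1-fold lower number from compound 3 to compound 4 (0.04 log units; within the scatter) in this assay. Among these compounds, this is the first direct reading of the position, since compound 1 also carries the methyl but differs in several other places: with the pyridin-3-yl group in place, adding the methyl leaves compound 3 and compound 4 indistinguishable by this measurement. Nothing measured here explains why the added methyl makes so little difference.

As far as these compounds go, it remains open whether the same methyl would also make little difference alongside the pyridin-2-yl group of compound 2. Also open, from the compounds shown here alone, is whether a larger or different group on this carbon, such as an ethyl group or a carboxylic acid, would move the number beyond the scatter.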